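Fluoro walk on the fused ring: compound 4

The compounds below may be only part of what the source reports. "The series", "measured", "known", "first", "only" and "open" are said of these compounds alone.

Compound 1 `O=C(Oc1ccccc1)N1CCC(CCn2ccc3cc(F)ccc32)CC1` — 130 nM
Compound 2 `O=C(Oc1ccccc1)N1CCC(CCn2ccc3cccc(F)c32)CC1` — 52 nM
Compound 3 `O=C(Oc1ccccc1)N1CCC(CCn2ccc3ccccc32)CC1` — 110 nM

In an assay on microsomes from brain for inhibition of Fatty-acid amide hydrolase 1 (Rattus norvegicus), read by HPLC, with a stated time of 60 min (a lower number here means a stronger inhibitor, a higher number a weaker inhibitor), compound 3 stands second highest of the three numbers; compound 1 is nearest, within the scatter, and compound 2 is furthest, beyond it. Compound 4 `O=C(Oc1ccccc1)N1CCC(CCn2ccc3c(F)cccc32)CC1` carries fluoro in place of hydrogen on an aromatic carbon. Within the data shown here, two measured steps bear on this: a 1.2-fold lower number from compound 1 to compound 3 (0.07 log units; within the scatter) and a 2.1-fold higher number from compound 2 to compound 3 (0.33 log units; beyond the scatter). Removing fluoro thus gave no step beyond the scatter in one case and a modest rise in the other. Adding fluoro here is therefore expected to lower the number modestly at most, and the expected step is a 1.4-fold lower number from compound 3 to compound 4 (0.14 log units; within the scatter). Compound 4 is estimated at 80 nM, range 40 nM to 180 nM.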

Compound 4, half-maximal inhibitory concentration: 110 nM
For compound 4 the middle estimate is 1.4-fold (0.14 log units) below the measured one, and the stated range covers the measured number.
By their numbers in this assay, from the lowest: compound 2; then compounds 3, 4 and 1 (each within the scatter of the next).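

In this assay, fluoro in place of hydrogen on this aromatic carbon, ortho to a fused ring and meta to a fused ring, gives no change at the digits printed from compound 3 to compound 4 (within the scatter). Compound 4 thus adds a second fluoro position with no step beyond the scatter, alongside compound 1, while compound 2 remains the only exception, with a 2.1-fold higher number from compound 2 to compound 3 (0.33 log units; beyond the scatter). No available evidence explains this dependence on position. Still open, from the compounds shown here alone, is whether chloro, methoxy or an amine on this same carbon would also leave the number unchanged.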